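A cyano swap on the chain of compound 3

The compounds below may be only part of what the source reports. "The series", "measured", "known", "first", "only" and "open" are said of these compounds alone.

In a functional assay on the whole organism with Rattus norvegicus as the target (a lower number here means that less compound is needed, a higher number that more compound is needed for the effect), compound 1 `Nc1nc2ccc(OC(F)(F)C(F)(F)F)cc2s1` gives 2.5 mg/kg as its dose for half-maximal effect. Compound 2 `Nc1nc2cccc(OC(F)(F)F)c2s1` stands at > 10 mg/kg which is a limit of the assay and not a number. Compound 3 `CCn1c(=N)sc2cc(OC(F)(F)F)ccc21` gives 5 mg/kg and so lies within the scatter of compound 1. Compound 4 `N#CCn1c(=N)sc2cc(OC(F)(F)F)ccc21` carries cyano in place of methyl on a saturated chain carbon bound to an aromatic nitrogen so that ethyl gives way to cyanomethyl. Among the measured compounds shown here, no pair of measured compounds sizes such a change, so the expectation rests on compound 3 at 5 mg/kg and no step beyond the scatter is expected in this assay in either direction. The estimated change a 1.2-fold higher number from compound 3 to compound 4 (0.08 log units; within the scatter) is accordingly small. Compound 4 is expected at 6 mg/kg within an estimated range of 2.5 mg/kg to 15 mg/kg for this dose.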

Compound 4, dose for half-maximal effect: 3.5 mg/kg
For compound 4 the middle estimate is 1.7-fold (0.23 log units) above the measured one; the measured number falls inside the stated range.
By their numbers in this assay, from the lowest: compounds 1, 4 and 3 (each within the scatter of the next). At a limit, above all of these: compound 2.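

Cyano in place of methyl on a saturated chain carbon bound to an aromatic nitrogen gives a 1.4-fold lower number from compound 3 to compound 4 (0.15 log units; within the scatter) in this assay. Among the compounds shown here, this is the first sized change at this position, and it shows that ethyl to cyanomethyl brings no step beyond the scatter. Nothing measured here accounts for this step.

The compounds shown leave open whether a longer chain, an amine or a carboxylic acid on this chain would bring a step beyond the scatter. They also leave open whether the same swap would give a similar step on another core.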